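Chromone vinyl sulfoxides: ester in place of ethoxy

This account rests on a few compounds, and the source may have more. Where it says the series, first, only, none or still open, it means among the compounds named here.

Measured compounds in a functional assay on DLD-1 cells (Homo sapiens) for cytotoxicity, with a stated time of 48 h; a lower number here means a stronger inhibitor, a higher number a weaker inhibitor:
compound 1 `COc1cccc2c(=O)cc(/C=C/[S+](C)[O-])oc12`: 9000 nM
compound 2 `Cc1ccc2oc(/C=C/[S+](C)[O-])cc(=O)c2c1`: 7000 nM
compound 3 `CCOc1ccc2oc(/C=C/[S+](C)[O-])cc(=O)c2c1`: 4900 nM

Compound 3 gives the lowest of the three numbers in this assay, but its gap to compound 2 and its gap to compound 1 both lie within the scatter, so the three compounds cannot be separated on these numbers. Among the compounds with values here, the single one-place step that has been measured, a 1.4-fold lower number from compound 2 to compound 3 (0.15 log units; within the scatter), is likewise within the scatter.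

Compound 4 `CC(C)C(=O)Oc1ccc2oc(/C=C/[S+](C)[O-])cc(=O)c2c1` differs from compound 3 in one place: isopropylcarbonyl in place of ethyl on an oxygen on an aromatic ring. Read one bond further out, the change is ethoxy to (isopropylcarbonyl)oxy. Within the data shown here, no measured step touches a change of this kind; the only measured step, from compound 2 to compound 3, swaps methyl for ethoxy on an aromatic carbon and moved the number within the scatter. The three measured compounds, with different groups at the shared core, all fall within the scatter of one another, so nothing here points to a step beyond the scatter in either direction for compound 4.

Compound 4 is therefore expected to give about 5000 nM in this assay, between 2000 nM and 12000 nM, a step of a 1.0-fold higher number from compound 3 to compound 4 (0.01 log units; within the scatter) that is expected to stay within the scatter.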

Compound 4, half-maximal inhibitory concentration: 9100 nM
Beside the measured number, compound 4's estimate is 1.8-fold (0.26 log units) below it; the range from low to high includes it.
By their numbers in this assay, from the lowest: compounds 3, 2, 1 and 4 (each within the scatter of the next).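

In this assay, the ester at this place, with isopropylcarbonyl in place of ethyl on an oxygen on an aromatic ring, gives a 1.9-fold higher number from compound 3 to compound 4 (0.27 log units; within the scatter) and so does not separate from the ether on these numbers. Set against the methyl compound, the same group gives a 1.3-fold higher number from compound 2 to compound 4 (0.11 log units; within the scatter) and again stays within the scatter, so a larger group carrying a carbonyl, with a hydrogen-bond acceptor that ethyl lacks, shows no readable effect here. No supporting data bear on these two steps.

Open, as far as these compounds go, is whether any group at this oxygen can move the number beyond the scatter in either direction. A free hydroxyl, an amine-bearing chain or a carboxylic acid on a longer chain would test this.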